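A few compounds are considered here, and "the series" means these few. Any claim that something is new, unique, unknown or untested is made for them only; others in the source may bear on it.

Measured so far in a functional assay on WiDr cells (Homo sapiens) for inhibition, read by sulforhodamine B assay, with a stated time of 48 h; a higher number here means a weaker inhibitor of growth, a lower number a stronger inhibitor of growth:
- compound 1 `COC(=O)[C@@]1(C)CCC=C2[C@@H]1CC[C@@H](C)[C@]2(C)Cc1c[nH]c2ccc(C)cc12` gives 22000 nM
- compound 2 `COC(=O)[C@@]1(C)CCC=C2[C@@H]1CC[C@@H](C)[C@]2(C)Cc1c[nH]c2ccc(Br)cc12` gives 20000 nM
- compound 3 `COC(=O)[C@@]1(C)CC[C@@H]2C3=C1CC[C@@H](C)[C@]3(C)Cc1c2[nH]c2ccc(C)cc12` gives 19000 nM

All three numbers lie within the usual scatter of one another. Compound 1 and compound 2 share a core and differ in one place: bromo in place of methyl on an aromatic carbon. In this assay that change made a 1.1-fold lower number from compound 1 to compound 2 (0.04 log units; within the scatter). Compound 3 has a different core from compound 1; the difference between the two cores is not broken down here.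

Compound 4 `COC(=O)[C@@]1(C)CC[C@@H]2C3=C1CC[C@@H](C)[C@]3(C)Cc1c2[nH]c2ccc(Br)cc12` is not yet measured. It differs from compound 3 by bromo in place of methyl on an aromatic carbon. This is the same kind of change as from compound 1 to compound 2, but in compound 3 the ring carrying it is part of a fused or bridged system of five rings, whereas in compound 1 it is part of a fused or bridged system of two rings. Going by the values given here, the only guide is the earlier pair, where the step was a 1.1-fold lower number from compound 1 to compound 2 (0.04 log units; within the scatter). On that basis the step from compound 3 to compound 4 is expected to be a 1.1-fold lower number from compound 3 to compound 4 (0.02 log units; within the scatter). Compound 4 is therefore estimated at 18000 nM, expected to fall between 9000 nM and 38000 nM in this assay.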

Compound 4, concentration for 50% growth inhibition: 22000 nM
The estimate for compound 4 lay 1.2-fold (0.09 log units) below the measured number, and the stated range covers the measured number.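

In this assay, bromo in place of methyl on the larger fused core gave a 1.2-fold higher number from compound 3 to compound 4 (0.06 log units; within the scatter), so on this core too the swap leaves the number within the usual scatter. This shows that the change behaved alike on both cores, with neither step standing out from repeated measurement: on neither core did it make a detectable difference to growth inhibition. Going by these compounds alone, it does not show that the change would behave the same way on other cores or in other assays, since only two pairs are available and a step this small cannot reveal any real but subtle difference between the cores. The comparison stands as follows: the same change on two cores in this assay, a 1.1-fold lower number (0.04 log units; within the scatter) from compound 1 to compound 2 and a 1.2-fold higher number (0.06 log units; within the scatter) from compound 3 to compound 4, 1.3-fold (0.11 log units) apart, within the scatter of two such steps.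

The compounds shown carry only methyl or bromo at this aromatic carbon, so it remains open whether an amine, a carboxylic acid or a longer chain there would move the number on either core. All four also keep the same methyl ester, so the effect of an amide in its place is open too.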